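Swapping a sulfur-bearing group for chlorine under a toxicity limit

The source may hold more compounds than are shown below. What is called first, only, known or untested is meant among the compounds shown, and "the series" means these compounds.

Compound 2 (`Cc1c(-c2ccc(Cc3ccc(S(=N)(=O)C(F)(F)F)cc3)cc2)[nH]c2cccc(F)c2c1=O`) gives no number to work from. In an ADME assay on Huh7.5.1 cells (Homo sapiens) for cytotoxicity, read by WST assay, with a stated time of 48 h (on this read-out higher numbers stand for lower toxicity in this test and lower numbers for higher toxicity in this test), compound 2 stands at > 10000 nM, which is a limit. Among the compounds with values here, the only other compound measured, compound 1 (`Cc1c(-c2ccc(Cc3ccc(C(C)(O)C(F)(F)F)cc3)cc2)[nH]c2cccc(F)c2c1=O`), also reports a limit, at > 2500 nM in this assay.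

The next compound, compound 3 (`Cc1c(-c2ccc(Cc3ccc(Cl)cc3)cc2)[nH]c2cccc(F)c2c1=O`), keeps the shared core and changes one substituent: one chlorine atom in place of a group of 7 heavy atoms (1 carbon, 1 nitrogen, 1 oxygen, 3 fluorine, 1 sulfur; no ring), on an aromatic carbon. It thus carries one chlorine atom where compound 2 has the larger group.

Within the data shown here, only one measured step bears on this change, a step that the two limits leave unreadable from compound 1 to compound 2. It also replaces the group on an aromatic carbon, but it has no readable size, so it gives neither a magnitude nor a direction to carry over. With compound 2 at > 10000 nM, no toxicity step beyond the usual scatter is expected, though this expectation rests on thin evidence. The expected change is a number no higher from compound 2 to compound 3 (the limit leaves the size open).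

For compound 3 the estimated value is 10000 nM, with an expected range from 3000 nM to 30000 nM.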

Compound 3, half-maximal cytotoxic concentration: > 10000 nM
Compound 3 ended at the assay's limit; the forecaster's own chance of this, stated with the estimate: 70%; the middle value lies on the limit itself.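

In this assay compound 3 gives > 10000 nM, which is a limit. No step can be read among compound 1, compound 2 and compound 3, as all three report only limits. The compounds shown leave open the actual half-maximal cytotoxic concentration of each, and whether the chloro group differs from either larger group.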